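From compound 2 to the formyl compound 3

This account rests on a few compounds, and the source may have more. Where it says the series, first, only, none or still open, it means among the compounds named here.

In a functional assay on A2780 cells (Homo sapiens) for cytotoxicity, read by sulforhodamine B assay, with a stated time of 96 h (a higher number here means that more compound is needed for the effect, a lower number that less compound is needed), compound 1 (`CCCC(=O)CC/C=C/C=C/C#CC#C/C=C/COC(C)=O`) gives 4700 nM and compound 2 (`CCCC(=O)CC/C=C/C=C/C#CC#C/C=C/COC(=O)CCl`) gives 3600 nM. Among the compounds with values here, the only measured step, a 1.3-fold lower number from compound 1 to compound 2 (0.12 log units; within the scatter), is chloro in place of hydrogen on a saturated chain carbon bound to a carbonyl carbon, so compound 2 does not stand apart from compound 1. Compound 3 (`CCCC(=O)CC/C=C/C=C/C#CC#C/C=C/C=O`) arises from compound 2 through formyl in place of (((chloromethyl)carbonyl)oxy)methyl on a double-bonded chain carbon bound to a double-bonded chain carbon. The measured step bears only weakly on this, since the whole group carrying that chloro leaves here, and the series holds no measured case of this replacement. No clear shift beyond the scatter is therefore expected in this assay. The expected step is a 1.8-fold lower number from compound 2 to compound 3 (0.26 log units; within the scatter). For compound 3 the estimated value is 2000 nM, with an expected range of 400 nM to 9000 nM.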

Compound 3, half-maximal effective concentration: 7000 nM
For compound 3 the middle estimate is 3.5-fold (0.54 log units) below the measured one, and the stated range covers the measured number.
By their numbers in this assay, from the lowest: compounds 2, 1 and 3 (each within the scatter of the next).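

In this assay, replacing either ester-bearing group with formyl on a double-bonded chain carbon bound to a double-bonded chain carbon gives a 1.9-fold higher number from compound 2 to compound 3 (0.29 log units; within the scatter) and a 1.5-fold higher number from compound 1 to compound 3 (0.17 log units; within the scatter). The group leaving compound 2 has 6 heavy atoms and formyl has 2, so this place accepts a much smaller group without a shift beyond the scatter, a wider change than the chloro step between the two esters. All three compounds therefore remain one group at this place, and no measured evidence bears on the result.

Open, as far as these compounds go, is whether an amine, a carboxylic acid or a longer chain at this place would stay within the same group. Also open, from the compounds shown here alone, is whether any change elsewhere on the shared core would move the number beyond the scatter.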